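The compounds below may be only part of what the source reports. "The series", "measured", "known", "first", "only" and "open" are said of these compounds alone.

Working notes on the series.

Compound 1 `CCOC(=O)c1sc(-c2cccc(NC(=O)c3ccccc3F)c2)nc1Nc1ccc(N2CCN(C)CC2)cc1` is the ethyl ester of the shared core. Among the compounds with values here, in a functional assay on Ramos cells (Homo sapiens) for antiproliferative activity, read by CCK-8 assay, with a stated time of 72 h (a higher number here means a weaker inhibitor, a lower number a stronger inhibitor), compound 1 gives 2000 nM, and this is the only number in the set so far. Compound 2 `CCOC(=O)c1sc(-c2cccc(NC(=O)c3ccc(C(F)(F)F)cn3)c2)nc1Nc1ccc(N2CCN(C)CC2)cc1`, which differs in the amide portion, carries no result in this assay: for compound 2 the entry reads "not determined" (no result reported), so nothing can be said of how it compares with compound 1.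

Compound 3 `CN1CCN(c2ccc(Nc3nc(-c4cccc(NC(=O)c5ccccc5F)c4)sc3C(=O)O)cc2)CC1` is the free acid belonging to compound 1. The change from compound 1 to compound 3 is hydrogen in place of ethyl on an oxygen next to a carbonyl group. Within the data shown here, no pair of measured compounds shows this change, so there is no measured step to lean on.

Within this cell-based read-out the expectation is that compound 3 will be somewhat weaker than compound 1, with a step from compound 1 to compound 3 of about a 2.5-fold higher number from compound 1 to compound 3 (0.40 log units; beyond the scatter), which is expected to fall somewhat beyond the usual scatter.

On that basis compound 3 is estimated at 5000 nM in this assay, within a range from 1500 nM to 20000 nM.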

Compound 3, half-maximal inhibitory concentration: 6300 nM
Beside the measured number, compound 3's estimate is 1.3-fold (0.10 log units) below it; the measured number falls inside the stated range.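

Within the data shown here, this is the first measured step at this position: with hydrogen in place of ethyl on an oxygen next to a carbonyl group, this assay shows a 3.2-fold higher number from compound 1 to compound 3 (0.50 log units; beyond the scatter), a modest change in size but one that stands clear of the scatter. The position is therefore not silent to this change, and ethoxycarbonyl to carboxy costs some potency without removing the read-out altogether, as compound 3 still gives 6300 nM in this assay on the same core. Nothing at hand bears on what lies behind this step.

The step rests on a single pair carrying the amide portion of compound 1, so its size with any other amide portion remains an open question. Also open, going by these compounds, is how a methyl ester, a longer alkyl ester or a primary carboxamide in this place would read against compound 1 and compound 3, and so whether the ethyl group itself matters or only the loss of the ester.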